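The source may hold more compounds than are shown below. What is called first, only, known or untested is meant among the compounds shown, and "the series" means these compounds.

Compound 1 `Cc1cc(Nc2ccn(Cc3cccc4ccccc34)n2)n2nc(SCc3ccc(Br)cc3)nc2n1` gives 3240 nM
Compound 2 `Cc1cc(Nc2cc(-c3ccccc3)[nH]n2)n2nc(SCC(=O)c3ccccc3)nc2n1` gives 2580 nM
Compound 3 `Cc1cc(Nc2cc(C(C)(C)C)[nH]n2)n2nc(SCc3ccc(Br)cc3)nc2n1` gives 5620 nM

These three compounds were tested in a functional assay on MGC-803 cells (Homo sapiens) for inhibition, read by MTT assay, with a stated time of 72 h; a lower number here means a stronger inhibitor, a higher number a weaker inhibitor. Compound 2 has the lowest number of the set, but its lead over compound 1 lies within the scatter, so those two cannot be told apart. Only compound 3 stands clearly apart from compound 2, as a weaker inhibitor beyond the scatter.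

The next compound is compound 4 `C=CCSc1nc2nc(C)cc(Nc3cc(-c4ccccc4)[nH]n3)n2n1`, which keeps the core and the phenyl-bearing side of compound 2 and changes the group on the sulfur chain. The change is vinyl in place of benzoyl on a saturated chain carbon bound to a sulfur. The same difference can be read as benzoylmethyl to allyl. All three measured compounds carry a six-membered aromatic ring of carbon only on that chain, and compound 4 does not. Within the data shown here, no measured pair differs in one place, so no step shows directly what this change does in this assay. Among the measured compounds shown here, the only guide is the spread of values, from compound 2 at 2580 nM to compound 3 at 5620 nM. A moderate loss of inhibition is therefore expected, though a step within the scatter cannot be ruled out. The expected change is a 2.3-fold higher number from compound 2 to compound 4 (0.37 log units; beyond the scatter), towards a weaker inhibitor. For compound 4 the estimated value is 6000 nM, with an expected range from 2200 nM to 18000 nM.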

Compound 4, half-maximal inhibitory concentration: 17200 nM
For compound 4 the middle estimate is 2.9-fold (0.46 log units) below the measured one; measured number inside the range.
By their numbers in this assay, from the lowest: compounds 2, 1 and 3 (each within the scatter of the next, the first and the last beyond it); then compound 4.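

In this assay, among these compounds, vinyl in place of benzoyl on a saturated chain carbon bound to a sulfur gives a 6.7-fold higher number from compound 2 to compound 4 (0.82 log units; beyond the scatter), a step towards a weaker inhibitor and the first change in this set that can be read at a single place. It shows that the group on the sulfur chain affects the result in this assay, and that with the core and the phenyl-bearing side unchanged, allylsulfanyl does not match (benzoylmethyl)sulfanyl. The change removes the six-membered aromatic ring of carbon only and the hydrogen-bond acceptor of the benzoyl together, so this single step cannot assign the loss to either one, and nothing available offers a cause for it.

Acetyl in place of benzoyl would keep the carbonyl without the ring, while a plain benzyl group would keep the ring without the carbonyl, and the compounds shown include neither. Going by these compounds, it also remains open whether a longer alkyl chain, or an amine or a carboxylic acid at the end of the chain, would stay near compound 2 or near compound 4.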